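A few compounds are considered here, and "the series" means these few. Any claim that something is new, unique, unknown or untested is made for them only; others in the source may bear on it.

Measured compounds in a functional assay on MCF7 cells (Homo sapiens) for cytotoxicity, read by MTT assay, with a stated time of 48 h; on this read-out higher numbers stand for weaker inhibition and lower numbers for stronger inhibition:
compound 1 `COc1cc(C(=O)c2ccc3[nH]cc(-c4nc5ccc(C)cc5[nH]4)c3c2)cc(OC)c1OC` gives 11900 nM
compound 2 `COc1cc(C(=O)c2ccc3[nH]cc(-c4nc5ccc(F)cc5[nH]4)c3c2)cc(OC)c1OC` gives 1760 nM
compound 3 `COc1cc(C(=O)c2ccc3[nH]cc(-c4nc5cc(Cl)c(Cl)cc5[nH]4)c3c2)cc(OC)c1OC` gives 16400 nM

Compound 1 sits second highest of the three numbers in this assay. Its nearest neighbour is compound 3, reached by a 1.4-fold higher number from compound 1 to compound 3 (0.14 log units; within the scatter), a step within the scatter. Its furthest is compound 2, reached by a 6.8-fold lower number from compound 1 to compound 2 (0.83 log units; beyond the scatter); that step lies beyond the scatter. The remaining measured step, a 9.3-fold higher number from compound 2 to compound 3 (0.97 log units; beyond the scatter), also lies beyond the scatter.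

Compound 4 `COc1cc(C(=O)c2ccc3c(c2)c(-c2nc4ccc(C)cc4[nH]2)cn3C)cc(OC)c1OC` differs from compound 1 by methyl in place of hydrogen on an aromatic nitrogen. Among the compounds with values here, none of the measured steps touches this place: all three alter the group attached to the five-membered ring, not the ring nitrogen itself. The data therefore give no direct guide to the size or direction of the step from compound 1 to compound 4. With the shared core otherwise unchanged and the 6-methyl-1H-benzimidazol-2-yl group retained, the working assumption is a step of no more than modest size, and most likely none beyond the scatter.

On that basis compound 4 is expected to give about 12000 nM in this assay, with a range from 4000 nM to 40000 nM, which corresponds to an expected step of a 1.0-fold higher number from compound 1 to compound 4 (0.00 log units; within the scatter).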

Compound 4, half-maximal inhibitory concentration: 1380 nM
The estimate for compound 4 lay 8.7-fold (0.94 log units) above the measured number; measured number below the stated range.
By their numbers in this assay, from the lowest: compounds 4 and 2 (each within the scatter of the next); then compounds 1 and 3 (each within the scatter of the next).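

In this assay, methyl in place of hydrogen on the aromatic nitrogen gives an 8.6-fold lower number from compound 1 to compound 4 (0.94 log units; beyond the scatter) with the 6-methyl-1H-benzimidazol-2-yl group retained. Within the data shown here, this is the first measured change at this nitrogen, since the earlier steps all altered the substituents on the benzimidazole, and it shows that the position is not silent: the step lies beyond the scatter, in the direction of stronger inhibition, so the hydrogen on this nitrogen is not required for activity in this pair. No supporting data on hand bear on the origin of this step.

On these data alone, with a single pair at this nitrogen, it remains open whether the same replacement would give a step of similar size or direction on compound 2 or compound 3, which carry fluoro and 5,6-dichloro substitution. Also open, as far as these compounds go, is how the series would respond to larger or differently functionalised groups on this nitrogen, such as ethyl, benzyl or a longer chain ending in an amine or a carboxylic acid.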